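Swapping the Nitro Group for a Methyl Group

This account rests on a few compounds, and the source may have more. Where it says the series, first, only, none or still open, it means among the compounds named here.

Going by the values given here, compound 2 `O=[N+]([O-])c1cccc(CSc2ncnc3c2ncn3[C@@H]2O[C@H](CO)[C@@H](O)[C@H]2O)c1` shows the lowest number of the two measured so far in an assay on isolated protein for inhibition of Equilibrative nucleoside transporter 1 (Homo sapiens) (on this read-out higher numbers stand for weaker inhibition and lower numbers for stronger inhibition), giving 1.78 nM. Compound 1 `OC[C@H]1O[C@@H](n2cnc3c(SCc4ccccc4I)ncnc32)[C@H](O)[C@@H]1O` gives 19.5 nM in this assay. Compound 3 `Cc1ccc(CSc2ncnc3c2ncn3[C@@H]2O[C@H](CO)[C@@H](O)[C@H]2O)cc1` is not yet measured; it differs from compound 2 by 4-methylphenyl in place of 3-nitrophenyl on a saturated chain carbon bound to a sulfur. Among the compounds with values here, the only comparable step, an 11-fold lower number from compound 1 to compound 2 (1.04 log units; beyond the scatter), shows that changing the group on this carbon can move the number a great deal. Since compound 2 carries the group that gave the lowest number, compound 3 is expected to give a higher number, estimated as a 5.6-fold higher number from compound 2 to compound 3 (0.75 log units; beyond the scatter), around 10 nM with a likely range from 3 nM to 40 nM.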

Compound 3, inhibition constant: 15.1 nM
Estimate against measurement, compound 3: 1.5-fold (0.18 log units) below; measured number inside the range.
By their numbers in this assay, from the lowest: compound 2; then compounds 3 and 1 (each within the scatter of the next).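

In this assay the change to 4-methylphenyl on this saturated chain carbon bound to a sulfur gives an 8.5-fold higher number from compound 2 to compound 3 (0.93 log units; beyond the scatter) and so gives up most of what 3-nitrophenyl gained. The other new step, a 1.3-fold lower number from compound 1 to compound 3 (0.11 log units; within the scatter), leaves 4-methylphenyl and 2-iodophenyl indistinguishable, so 3-nitrophenyl alone stands apart among these three groups. No measurement here accounts for this difference. The nitro and methyl groups differ in both identity and ring place, so 3-methylphenyl would be needed to separate the two. As far as these compounds go, it also remains open how a phenyl ring carrying an amine or a carboxylic acid would fare.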